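Alkylamino pyrazine benzylamides and their cytotoxicity in canine kidney cells

The source may report more compounds than this note shows. Statements on the series, on what has been measured and on what is new or still open speak of the compounds shown alone.

Measured compounds:
compound 1, `CCCCNc1nccnc1C(=O)NCc1ccccc1`, in an ADME assay on MDCK cells (Canis lupus familiaris) for cytotoxicity, read by microscopy, with a stated time of 6 days (on this read-out lower numbers stand for higher toxicity in this test and higher numbers for lower toxicity in this test), compound 1 gives > 100000 nM, which is a limit of the assay and not a number.
compound 2, `CCCCCCNc1nccnc1C(=O)NCc1ccccc1`, in this assay compound 2 gives 100000 nM.
compound 3, `CCCCCCCNc1nccnc1C(=O)NCc1ccccc1`, in this assay compound 3 gives 100000 nM.

The three compounds share one core and differ only in the length of the alkyl chain on the aromatic nitrogen. Compound 1 sits at the limit of this assay, as the evidence shows: the limit of > 100000 nM in this assay, at which 1 of the 3 values shown sits. Compound 2 and compound 3 differ by methyl in place of hydrogen on a saturated chain carbon, six bonds along the chain from a nitrogen on an aromatic ring, and the step of no change at the digits printed from compound 2 to compound 3 (within the scatter) lies within the scatter. From compound 2 to compound 1 the change is hydrogen in place of ethyl on a saturated chain carbon, four bonds along the chain from a nitrogen on an aromatic ring, and the step of a number no lower from compound 2 to compound 1 (the limit leaves the size open) is left open in size by the limit. Likewise the step of a number no higher from compound 1 to compound 3 (the limit leaves the size open) cannot be sized.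

Compound 4, `CCCCCNc1nccnc1C(=O)NCc1ccccc1`, is not yet measured in this assay. It differs from compound 3 by hydrogen in place of ethyl on a saturated chain carbon, five bonds along the chain from a nitrogen on an aromatic ring. This is the same kind of change as from compound 2 to compound 1, but the place differs: there it sits four bonds along the chain from a nitrogen on an aromatic ring, here five bonds. Because the step of no change at the digits printed from compound 2 to compound 3 (within the scatter) shows no change within the scatter, compound 4 is expected to sit close to compound 3, with no change at the digits printed from compound 3 to compound 4 (within the scatter). The estimate for compound 4 in this assay is 100000 nM, expected between 50000 nM and 200000 nM.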

Compound 4, minimum cytotoxic concentration: >= 20000 nM
Compound 4 was reported as a limit; the forecaster's own chance of this, stated with the estimate: 40%; the middle value is on the limit's open side.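

In this assay compound 4 gives >= 20000 nM, which is a limit of the assay and not a number. Among these compounds, no step from compound 1, compound 2 or compound 3 to compound 4 can be read from this result. The compounds shown leave open where the true value of compound 4 lies relative to the other three, and whether chain length affects this read-out at all.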